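The source may report more compounds than this note shows. Statements on the series, on what has been measured and on what is new or still open speak of the compounds shown alone.

Compound 2 `c1ccc2nc(COc3ccc(CCc4nnn[nH]4)cc3)ccc2c1` gives 280 nM in a functional assay (Cavia porcellus) for inhibition of cysteinyl leukotriene receptor (Homo sapiens); on this read-out lower numbers stand for stronger inhibition and higher numbers for weaker inhibition. Among the three measured compounds it stands second highest: compound 1 `c1cc(OCc2ccc3ccccc3n2)cc(-c2nn[nH]n2)c1` gives 200 nM, a number within the usual scatter of that of compound 2, while compound 3 `CCOC(=O)CCCOc1cccc(OCc2ccc3ccccc3n2)c1` gives 600 nM, a gap beyond the scatter. Compound 4 `O=C(O)CCCOc1ccc(OCc2ccc3ccccc3n2)cc1` differs from compound 2 in one place: 3-carboxypropoxy in place of 2-(1H-tetrazol-5-yl)ethyl on an aromatic carbon. One measured step resembles this change, in which a tetrazole ring also gave way to an oxygen-linked chain carrying a carbonyl, and it weakened inhibition modestly, a 3.0-fold higher number from compound 1 to compound 3 (0.48 log units; beyond the scatter). A step of similar size and direction is expected here, a 2.0-fold higher number from compound 2 to compound 4 (0.29 log units; within the scatter), because the step of a 3.0-fold higher number from compound 1 to compound 3 (0.48 log units; beyond the scatter) was modest but beyond the scatter. Compound 4 is therefore estimated at 550 nM, with a likely range from 220 nM to 1400 nM.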

Compound 4, half-maximal inhibitory concentration: 800 nM
Estimate against measurement, compound 4: 1.5-fold (0.16 log units) below; the measured number falls inside the stated range.
By their numbers in this assay, from the lowest: compounds 1 and 2 (each within the scatter of the next); then compounds 3 and 4 (each within the scatter of the next).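

On the aromatic carbon para to a large group, replacing the tetrazole-bearing chain with a ring-free chain of the same heavy-atom count, ending in a free carboxyl group, weakens inhibition in this assay: a 2.9-fold higher number from compound 2 to compound 4 (0.46 log units; beyond the scatter). So the loss seen earlier with an ester-ended chain also appears with a chain ending in a carboxylic acid, at a different place on the ring. Nothing shown explains this loss. On these data alone, how a longer chain ending in a carboxylic acid, or an amide in the same place, would compare remains open.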